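The source may report more compounds than this note shows. Statements on the series, on what has been measured and on what is new or still open speak of the compounds shown alone.

Compound 1, `COc1cc2ncnc(Nc3ccc(F)c(Cl)c3)c2cc1OCCCCC(=O)Nc1ccc(S(N)(=O)=O)cc1`: 5020 nM
Compound 2, `COc1cc2ncnc(Nc3cccc(F)c3)c2cc1OCCCCC(=O)Nc1ccc(S(N)(=O)=O)cc1`: 29900 nM
Compound 3, `COc1ccc(Nc2ncnc3cc(OC)c(OCCCCC(=O)Nc4ccc(S(N)(=O)=O)cc4)cc23)cc1OC`: 35400 nM

Three compounds sharing one core were tested in a functional assay on A-431 cells (Homo sapiens) for antiproliferative activity, read by MTT assay, with a stated time of 72 h; a higher number here means a weaker inhibitor, a lower number a stronger inhibitor. Compound 1 gave 5020 nM, compound 2 gave 29900 nM, and compound 3 gave 35400 nM. Among these numbers compound 2 holds the second highest; its nearest neighbour is compound 3, whose number lies within the scatter of its own, while compound 1 is furthest, with a 6.0-fold higher number from compound 1 to compound 2 (0.77 log units; beyond the scatter). The other departure from compound 1, a 7.1-fold higher number from compound 1 to compound 3 (0.85 log units; beyond the scatter), is of the same order, and a 1.2-fold higher number from compound 2 to compound 3 (0.07 log units; within the scatter) separates the two weaker compounds.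

Compound 4, `COc1cc2ncnc(Nc3cccc(C)c3)c2cc1OCCCCC(=O)Nc1ccc(S(N)(=O)=O)cc1`, has not yet been measured in this assay. It differs from compound 2 by methyl in place of fluoro on an aromatic carbon. Within the data shown here, no measured step exchanges fluoro for methyl at that position; the steps that bear on it are those that alter the same aryl ring, and the closest of them, a 1.2-fold higher number from compound 2 to compound 3 (0.07 log units; within the scatter), shows that a change on this ring can leave the number nearly where it was. Compound 4 is therefore expected to sit close to compound 2, with a 1.1-fold lower number from compound 2 to compound 4 (0.03 log units; within the scatter) expected to stay within the scatter. The estimated value for compound 4 is 28000 nM, with a range from 10000 nM to 75000 nM.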

Compound 4, half-maximal inhibitory concentration: 7460 nM
Compound 4: the middle estimate sits 3.8-fold (0.57 log units) above what was measured; the measured number lies below the stated range.
By their numbers in this assay, from the lowest: compounds 1 and 4 (each within the scatter of the next); then compounds 2 and 3 (each within the scatter of the next).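

In this assay, the exchange of fluoro for methyl on this aromatic carbon is not a silent one (a 4.0-fold lower number from compound 2 to compound 4 (0.60 log units; beyond the scatter)): a change of one heavy atom for one heavy atom, with the rest of the molecule untouched, moves the number by more than the scatter, which the earlier step between the 3-fluorophenyl and 3,4-dimethoxyphenyl compounds gave no sign of. Among these compounds, the 3-methylphenyl compound also stands apart from the 3,4-dimethoxyphenyl compound (a 4.7-fold lower number from compound 3 to compound 4 (0.68 log units; beyond the scatter)) but not from the 3-chloro-4-fluorophenyl compound (a 1.5-fold higher number from compound 1 to compound 4 (0.17 log units; within the scatter)), so the single methyl places compound 4 with compound 1 and not with compounds 2 and 3. Nothing measured here accounts for why methyl and fluoro part at this position.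

The compounds shown leave open whether the effect belongs to methyl alone or also extends to an ethyl, a chloro or an amine on the same carbon. They also leave open whether the gap between the 3-methylphenyl and 3-fluorophenyl compounds survives a longer chain in the linker or a carboxylic acid in place of the sulfonamide.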